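This account rests on a few compounds, and the source may have more. Where it says the series, first, only, none or still open, it means among the compounds named here.

Compound 1, with the structure `C(=C1\CCN=C1c1cccnc1)\c1ccccc1`, is the reference point of this account. In an assay for displacement of a labelled ligand from Nicotinic acetylcholine receptor alpha8 subunit (Periplaneta americana), read by scintillation counting, with a stated time of 2 h, at 24 degrees C, tested at 10 uM (a higher number here means more inhibition at the concentration tested (going by the name of the read-out), a lower number less inhibition), compound 1 gives 41.3%. Two close relatives have been measured alongside it. Compound 2 `Oc1cccc(/C=C2\CCN=C2c2cccnc2)c1` carries hydroxy in place of hydrogen on an aromatic carbon and in this assay compound 2 gives 32.1%. Compound 3 `COc1ccccc1/C=C1\CCN=C1c1cccnc1` carries methoxy in place of hydrogen on an aromatic carbon and in this assay compound 3 gives 49.5%. Among these three numbers compound 1 holds the second, yet neither neighbour is separated from it by more than the scatter: the change is a number 8.2 percentage points higher from compound 1 to compound 3 (within the scatter) and a number 9.2 percentage points lower from compound 1 to compound 2 (within the scatter).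

Compound 4 `Fc1ccc(/C=C2\CCN=C2c2cccnc2)cc1` is the next compound to be measured. It differs from compound 1 by fluoro in place of hydrogen on an aromatic carbon. The two steps already seen bear directly on this case, since each also replaces a hydrogen on the aromatic ring with a single small group, and each moved the number by less than the scatter. The same is therefore expected here: a step of a number 0.7 percentage points higher from compound 1 to compound 4 (within the scatter), with no movement beyond the scatter in either direction. Compound 4 is accordingly estimated to give 42% in this assay, within a range from 28% to 56%.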

Compound 4, a percentage reported as inhibition, at one concentration (the size of the read-out at that concentration, not a potency): 22.3%
Beside the measured number, compound 4's estimate is 19.7 percentage points above it; the measured number lies below the stated range.
By their numbers in this assay, from the lowest: compounds 4, 2, 1 and 3 (each within the scatter of the next, the first and the last beyond it).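

In this assay, going by these compounds alone, the fluoro replacement is the first of the changes on this aromatic ring to move the number beyond the scatter: a number 19 percentage points lower from compound 1 to compound 4 (beyond the scatter). The hydroxy and methoxy replacements stayed within the scatter, with a number 9.2 percentage points lower from compound 1 to compound 2 (within the scatter) and a number 8.2 percentage points higher from compound 1 to compound 3 (within the scatter), so replacing a hydrogen on this ring with a single small group cannot be taken as neutral in every case, and a fluoro on an aromatic carbon para to a large group is enough to lower the inhibition. Nothing available here explains why this step exceeds the scatter while the other two do not.

Whether the lower number belongs to fluoro as a group or to this particular place stays open, as the compounds shown do not separate the two. On these data alone, it also remains open what a chloro, an amine or a carboxylic acid on the aromatic carbon para to the large group would give, and whether any such group would lower the number as fluoro does or leave it within the scatter of compound 1.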